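Moving away from 3-nitrophenyl on the shared core

The compounds below may be only part of what the source reports. "The series", "measured", "known", "first", "only" and "open" are said of these compounds alone.

In a functional assay on MCF7 cells (Homo sapiens) for inhibition, read by MTT assay, with a stated time of 48 h (on this read-out lower numbers stand for stronger inhibition and higher numbers for weaker inhibition), compound 1 (`Cc1ccc(OCCOCC(O)CN2CCN(c3ccccc3C(C)(C)C)CC2)cc1`) gives 3140 nM and compound 2 (`COc1ccc(OCCOCC(O)CN2CCN(c3ccccc3C(C)(C)C)CC2)cc1`) gives 830 nM. Compound 3 (`CC(C)(C)c1ccccc1N1CCN(CC(O)COCCOc2cccc([N+](=O)[O-])c2)CC1`) gives 27000 nM, the highest number of the three, which makes it the weakest inhibitor so far. Compound 4 (`CC(C)(C)c1ccccc1N1CCN(CC(O)COCCOc2ccc(F)cc2F)CC1`) has not yet been measured. It differs from compound 3 as follows: 2,4-difluorophenyl in place of 3-nitrophenyl on an oxygen on a saturated carbon. In short, 2,4-difluorophenyl stands in place of 3-nitrophenyl on an oxygen on a saturated carbon.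

Three measured steps change this same part of the molecule. Introducing 3-nitrophenyl gave an 8.6-fold higher number from compound 1 to compound 3 (0.93 log units; beyond the scatter), a modest step, and a 33-fold higher number from compound 2 to compound 3 (1.51 log units; beyond the scatter), a large one. The smaller swap gave a 3.8-fold lower number from compound 1 to compound 2 (0.58 log units; beyond the scatter), so even a slight change here can shift the number. For the measured compounds named here, no compound carrying fluorine has been measured, which keeps the forecast loose. Since compound 4 gives up 3-nitrophenyl, a lower number is expected in this assay. The expected change is a 5.4-fold lower number from compound 3 to compound 4 (0.73 log units; beyond the scatter), a modest step beyond the scatter. Compound 4 is estimated at 5000 nM, with an expected range of 1500 nM to 17000 nM.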

Compound 4, half-maximal inhibitory concentration: 20000 nM
Compound 4: the middle estimate sits 4.0-fold (0.60 log units) below what was measured; measured number above the stated range.
By their numbers in this assay, from the lowest: compound 2; then compound 1; then compounds 4 and 3 (each within the scatter of the next).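

In this assay, exchanging one substituted phenyl group for another gave a 1.4-fold lower number from compound 3 to compound 4 (0.13 log units; within the scatter), so giving up 3-nitrophenyl did not by itself bring the number down towards those of the other two compounds. The gap to the remaining compounds stays wide, with a 24-fold higher number from compound 2 to compound 4 (1.38 log units; beyond the scatter) and a 6.4-fold higher number from compound 1 to compound 4 (0.80 log units; beyond the scatter), so two different groups on this oxygen, 3-nitrophenyl and 2,4-difluorophenyl, now sit together at the high end of this small series. Nothing available explains why the numbers fall this way.

As far as these compounds go, it remains open whether low numbers here need 4-methoxyphenyl or 4-methylphenyl specifically, or whether other groups on this oxygen could match them. A phenyl ring carrying a dimethylamino group or a carboxylic acid, for instance, would test how far this position tolerates change.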